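From pyridin-2-yl to pyridin-4-yl: working notes

The compounds below may be only part of what the source reports. "The series", "measured", "known", "first", "only" and "open" are said of these compounds alone.

Measured so far in an ADME assay on HeLa cells (Homo sapiens) for cytotoxicity, read by XTT assay, with a stated time of 3 days; on this read-out higher numbers stand for lower toxicity in this test and lower numbers for higher toxicity in this test
Compound 1 `C1=C(/C=C\c2cccnc2)COc2ccccc21` gives 37500 nM
Compound 2 `O=c1c(/C=C/c2ccccn2)coc2ccccc12` gives > 200000 nM
Compound 3 `O=c1c(/C=C/c2ccccn2)coc2ccc(Cl)cc12` gives > 50000 nM

Compound 2 stands at the limit of > 200000 nM in this assay, at which 1 of the 3 values shown sits, and this is a limit, not a number. Compound 3 stands at the limit of > 50000 nM in this assay, at which 1 of the 3 values shown sits, and this too is only a limit. For the measured compounds named here, compound 1 gives 37500 nM as the sole true number in this assay but is joined to compound 2 by no measured step.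

The change to compound 4 `O=c1c(/C=C/c2ccncc2)coc2ccccc12` is pyridin-4-yl in place of pyridin-2-yl on a double-bonded chain carbon bound to a double-bonded chain carbon with the same atoms joined differently. Going by the values given here, the one measured step is a step that the two limits leave unreadable from compound 2 to compound 3 and it offers no size to carry over. Among the compounds with values here, no measured step bears directly on this change, so no step beyond the scatter is expected in this assay for now. The expected step is an at least 1.3-fold lower number from compound 2 to compound 4 (0.12 log units; that floor lies within the scatter) on this basis. For compound 4 the estimate is 150000 nM with an expected range from 50000 nM to 300000 nM in this assay.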

Compound 4, half-maximal cytotoxic concentration: > 100000 nM
Compound 4 ended at the assay's limit; the forecaster's own chance of this, stated with the estimate: 50%; the middle value lies beyond the limit too.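

In this assay compound 2 and compound 4 both end at limits of the assay, not at numbers, and the step between them cannot be read. The compounds shown leave open whether pyridin-4-yl in place of pyridin-2-yl changes the read-out at all.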